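The compounds below may be only part of what the source reports. "The series", "measured", "known", "first", "only" and "open" are said of these compounds alone.

Measured so far in a functional assay on PC-3 cells (Homo sapiens) for inhibition, read by sulforhodamine B assay; a higher number here means a weaker inhibitor of growth, a lower number a stronger inhibitor of growth:
- compound 1 `Oc1cccc2[nH]c(-c3ccc(-c4ccc(-c5ccc(C(F)(F)F)cc5)cc4)cc3)nc12`: 2260 nM
- compound 2 `Oc1ccc(-c2ccc(-c3ccc(-c4nc5c(O)cccc5[nH]4)cc3)cc2)cc1`: 190 nM

Of these two, compound 2 holds the lower number, and compound 1 stands well above it. Next in the series is compound 3 `Oc1cccc2[nH]c(-c3ccc(-c4ccc(-c5cccc(Cl)c5)cc4)cc3)nc12`, with 3-chlorophenyl in place of 4-hydroxyphenyl on an aromatic carbon, para to a large group: 3-chlorophenyl in place of 4-hydroxyphenyl on an aromatic carbon. Going by the values given here, one measured step bears on this change: a 12-fold lower number from compound 1 to compound 2 (1.08 log units; beyond the scatter), large and beyond the scatter, with hydroxy in place of trifluoromethyl. Compound 3 also gives up the hydroxy, so a large step to a higher number in this assay is expected, of similar or somewhat smaller size. Among the compounds with values here, this rests on a single pair, and no measured compound carries chlorine. The estimated change is a 7.4-fold higher number from compound 2 to compound 3 (0.87 log units; beyond the scatter). For compound 3 the expected value is 1400 nM, with an estimated range of 450 nM to 4000 nM.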

Compound 3, concentration for 50% growth inhibition: 2560 nM
Estimate against measurement, compound 3: 1.8-fold (0.26 log units) below; low and high end bracket the measured number.
By their numbers in this assay, from the lowest: compound 2; then compounds 1 and 3 (each within the scatter of the next).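

In this assay, the change to 3-chlorophenyl gives a 13-fold higher number from compound 2 to compound 3 (1.13 log units; beyond the scatter), so a second group in place of 4-hydroxyphenyl, with a different substituent at a different ring place, also goes with a large step to a higher number. Exchanging 4-(trifluoromethyl)phenyl for 3-chlorophenyl gives a 1.1-fold higher number from compound 1 to compound 3 (0.05 log units; within the scatter), so these two groups cannot be told apart here, and among the three compounds only the 4-hydroxyphenyl compound stands apart. Nothing at hand offers an explanation for this result.

On these data alone, compound 3 moves the substituent as well as changing it, so the part played by its ring place stays open, and 3-hydroxyphenyl and 4-chlorophenyl would bear on that. Also open, as far as these compounds go, is whether an amine or a carboxylic acid on the terminal phenyl ring would keep the low number of compound 2.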